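Swapping the sulfonamide substituent: permeability outlook for compound 4

The source may hold more compounds than are shown below. What is called first, only, known or untested is meant among the compounds shown, and "the series" means these compounds.

Measured so far in an ADME assay on Caco-2 cells (Homo sapiens) for permeability, in the apical to basolateral direction; on this read-out lower numbers stand for lower permeability and higher numbers for higher permeability:
- compound 1, `CCC(=O)N1CCC(CN(C2Cc3cc(C#N)ccc3N(Cc3cncn3C)C2)S(=O)(=O)c2ccccn2)CC1`, gives 0.5 10^-6 cm/s
- compound 2, `CCCC(=O)N1CCC(CN(C2Cc3cc(C#N)ccc3N(Cc3cncn3C)C2)S(=O)(=O)c2ccccn2)CC1`, gives 0.5 10^-6 cm/s
- compound 3, `Cn1cncc1CN1CC(N(Cc2ccc(S(C)(=O)=O)cc2)S(=O)(=O)c2ccccn2)Cc2cc(C#N)ccc21`, gives 0.2 10^-6 cm/s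

Compound 3 has the lowest number of the three; the steps of a 2.5-fold lower number from compound 1 to compound 3 (0.40 log units; beyond the scatter) and a 2.5-fold lower number from compound 2 to compound 3 (0.40 log units; beyond the scatter) both lie beyond the scatter, while the step of no change at the digits printed from compound 1 to compound 2 (within the scatter) does not. Compound 4, `Cc1noc(C)c1CN(C1Cc2cc(C#N)ccc2N(Cc2cncn2C)C1)S(=O)(=O)c1ccccn1`, is not yet measured. It differs from compound 3 by 3,5-dimethyl-1,2-oxazol-4-yl in place of 4-(methylsulfonyl)phenyl on a saturated chain carbon bound to a sulfonamide nitrogen. For the measured compounds named here, no measured step involves the entering group, so the change cannot be matched directly. The two steps that do bear on the same position, from compound 1 and from compound 2 to compound 3, were modest and both lowered the number when the group now leaving was introduced. Removing it again is therefore expected to move the number back up by a modest amount, roughly a 2.5-fold higher number from compound 3 to compound 4 (0.40 log units; beyond the scatter), with wide uncertainty. For compound 4 the estimated value in this assay is 0.5 10^-6 cm/s, within a range from 0.2 10^-6 cm/s to 1.2 10^-6 cm/s.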

Compound 4, apparent permeability: 8 10^-6 cm/s
Compound 4: middle estimate off by 16-fold (1.20 log units), on the low side; the measured number lies above the stated range.
By their numbers in this assay, from the lowest: compound 3; then compounds 1 and 2 (each within the scatter of the next); then compound 4.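

In this assay, for the compounds shown here, the group on the saturated chain carbon bound to a sulfonamide nitrogen turns out to have far more influence than the earlier compounds revealed: 3,5-dimethyl-1,2-oxazol-4-yl in place of 4-(methylsulfonyl)phenyl gives a 40-fold higher number from compound 3 to compound 4 (1.60 log units; beyond the scatter). The entering group also stands well clear of both compounds with a piperidine-based group at this place, with a 16-fold higher number from compound 1 to compound 4 (1.20 log units; beyond the scatter) and a 16-fold higher number from compound 2 to compound 4 (1.20 log units; beyond the scatter), so the change does more than recover the ground lost with 4-(methylsulfonyl)phenyl. Nothing available here bears on what lies behind this jump.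

Still open, going by these compounds, is whether the five-membered ring or its two methyl groups accounts for the step, a question that a plain phenyl or a 1,2-oxazol-4-yl without the methyls could help to separate. On these data alone, how an amine at this place would compare also remains unknown.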